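The compounds below may be only part of what the source reports. "The series", "measured", "known", "first", "only" and "open" are said of these compounds alone.

Measured so far:
Compound 1, `CCCSc1nc(N/N=C(\C)c2ccc(OC)cc2)c2nnn(Cc3ccccc3)c2n1`: in a functional assay on MCF7 cells (Homo sapiens) for antiproliferative activity, read by MTT assay, with a stated time of 72 h (on this read-out higher numbers stand for weaker inhibition and lower numbers for stronger inhibition), compound 1 returns only the assay limit, > 64000 nM.
Compound 2, `CCCSc1nc(N/N=C(\C)c2ccccc2O)c2nnn(Cc3ccco3)c2n1`: in this assay compound 2 gives 29000 nM.
Compound 3, `CCCSc1nc(N/N=C/c2ccc(C)cc2)c2nnn(Cc3ccccc3)c2n1`: in this assay compound 3 returns only the assay limit, > 64000 nM.

Compound 3 therefore stands at a limit and not at a number; the same limit is the limit of > 64000 nM in this assay, at which 2 of the 3 values shown sit. Of the three compounds only compound 2 returns a number, and that a weak one. For the measured compounds named here, none of the measured compounds differ from one another in a single place, so no measured step is available to calibrate any change.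

Compound 4, `CCCSc1nc(N/N=C/c2c[nH]c3ccccc23)c2nnn(Cc3ccccc3)c2n1`, is not yet measured. It differs from compound 3 by 1H-indol-3-yl in place of 4-methylphenyl on a carbon with a double bond to nitrogen. Going by the values given here, no measured pair covers a change of this kind, so nothing here sets its size or direction. With compound 3 at the limit, the step of an at least 1.0-fold lower number from compound 3 to compound 4 (0.02 log units; that floor lies within the scatter) is expected to stay within the scatter, and a further limit is as likely as a number. Compound 4 is estimated at 60000 nM, with a range from 20000 nM to 200000 nM.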

Compound 4, half-maximal inhibitory concentration: 9010 nM
Estimate against measurement, compound 4: 6.7-fold (0.82 log units) above; measured number below the stated range.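

This position, on a carbon with a double bond to nitrogen, is the only place in the series where a single change can be read: 1H-indol-3-yl in place of 4-methylphenyl gives an at least 7.1-fold lower number from compound 3 to compound 4 (0.85 log units; beyond the scatter) in this assay. For the compounds shown here, the group here can therefore bring the read-out off the limit with the rest of the molecule held fixed, which the earlier compounds, differing from one another in more than one place, could not show. The step has only a floor and no full size, because its starting point is a limit and not a number: the limit of > 64000 nM in this assay, at which 2 of the 4 values shown sit.

Still open, from the compounds shown here alone, is whether the step follows from the hydrogen-bond donor of the 1H-indol-3-yl or from its second ring, which a naphthyl or an N-methylindolyl group at this position would separate. Also open, going by these compounds, is whether the step holds with other groups elsewhere on the shared core.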